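Vero cytotoxicity notes: aryl-oxazole chalcone amides

The compounds below may be only part of what the source reports. "The series", "measured", "known", "first", "only" and "open" are said of these compounds alone.

Compound 1 `COC(=O)c1cc(-c2cccc(NC(=O)c3ccc(/C=C/C(=O)c4ccccc4)cc3)c2)on1` gives > 50 ug/mL in an ADME assay on Vero cells (Chlorocebus sabaeus) for cytotoxicity, read by MTT assay, with a stated time of 72 h; on this read-out lower numbers stand for higher toxicity in this test and higher numbers for lower toxicity in this test; this is a limit of the assay, not a number.
Compound 2 `CCOc1ccc(C(=O)/C=C/c2ccc(C(=O)Nc3cccc(-c4cc(C(=O)OC)no4)c3)cc2)cc1` gives > 40 ug/mL in this assay, again a limit.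
Compound 3 `COC(=O)c1cc(-c2cccc(NC(=O)c3ccc(/C=C/C(=O)c4ccc(C)c([N+](=O)[O-])c4)cc3)c2)on1` gives > 80 ug/mL in this assay, again a limit.

Compound 3 therefore stands only at a limit, as do the other two compounds. Among the compounds with values here, the steps a step that the two limits leave unreadable from compound 1 to compound 2, a step that the two limits leave unreadable from compound 1 to compound 3 and a step that the two limits leave unreadable from compound 2 to compound 3 are all unreadable, so no measured step gives a size or direction. Compound 4 `COC(=O)c1cc(-c2cccc(NC(=O)c3ccc(/C=C/C(=O)c4ccc(CC(C)C)cc4)cc3)c2)on1` differs from compound 3 by 4-isobutylphenyl in place of 4-methyl-3-nitrophenyl on a carbonyl carbon. No step beyond the scatter is expected, so the estimated step is a number no higher from compound 3 to compound 4 (the limit leaves the size open). Compound 4 is expected to give about 80 ug/mL, in the range 40 ug/mL to 160 ug/mL, most likely again as a limit.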

Compound 4, half-maximal cytotoxic concentration: > 10 ug/mL
Compound 4 ended at the assay's limit (the forecaster's own chance of this, stated with the estimate: 75%); the middle value is on the limit's open side.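

In this assay compound 4 gives > 10 ug/mL, a limit of the assay. Its steps to compound 1, compound 2 and compound 3, also limits, cannot be read. As far as these compounds go, the actual cytotoxic concentrations of all four compounds, and any effect of these changes, remain open.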